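Thiosemicarbazone versus benzyl isothiosemicarbazone on two anilino cores

The source may report more compounds than this note shows. Statements on the series, on what has been measured and on what is new or still open speak of the compounds shown alone.

Measured so far in a functional assay on HCT-116 cells (Homo sapiens) for antiproliferative activity, read by MTT assay, with a stated time of 72 h; on this read-out lower numbers stand for stronger inhibition and higher numbers for weaker inhibition:
compound 1 `Cc1ccccc1NC1=C/C(=N/NC(N)=S)C(=O)N=C1Nc1ccccc1C`, 1520 nM;
compound 2 `NC(=S)N/N=C1/C=C(Nc2cccc(Cl)c2)C(Nc2cccc(Cl)c2)=NC1=O`, 3380 nM;
compound 3 `Cc1ccccc1NC1=C/C(=N/N=C(\N)SCc2ccccc2)C(=O)N=C1Nc1ccccc1C`, 13800 nM.

Compound 1 and compound 3 differ in one place: a group of 11 heavy atoms (8 carbon, 2 nitrogen, 1 sulfur; one six-membered aromatic ring of carbon only) in place of a group of 4 heavy atoms (1 carbon, 2 nitrogen, 1 sulfur; no ring), on a double-bonded nitrogen. This change gives a 9.1-fold higher number from compound 1 to compound 3 (0.96 log units; beyond the scatter). Compound 2 carries a different core; the difference between the core of compound 2 and the core of compound 1 is not broken down here. In this assay compound 2 gives a number higher than that of compound 1 and lower than that of compound 3, both gaps beyond the scatter.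

Compound 4 `N/C(=N\N=C1\C=C(Nc2cccc(Cl)c2)C(Nc2cccc(Cl)c2)=NC1=O)SCc1ccccc1` has not yet been measured. It differs from compound 2 by a group of 11 heavy atoms (8 carbon, 2 nitrogen, 1 sulfur; one six-membered aromatic ring of carbon only) in place of a group of 4 heavy atoms (1 carbon, 2 nitrogen, 1 sulfur; no ring), on a double-bonded nitrogen. This is the same change as that from compound 1 to compound 3, at the same place, and it occurs only that once among the measured compounds. Going by the values given here, the only guide is the step of a 9.1-fold higher number from compound 1 to compound 3 (0.96 log units; beyond the scatter) seen with compound 1 and compound 3. For compound 2 a step of similar size is expected, namely a 7.4-fold higher number from compound 2 to compound 4 (0.87 log units; beyond the scatter), with wider uncertainty because a single occurrence on one core need not carry over unchanged. Compound 4 is thus estimated at 25000 nM in this assay, expected to lie between 8000 nM and 70000 nM.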

Compound 4, half-maximal inhibitory concentration: 11700 nM
Estimate against measurement, compound 4: 2.1-fold (0.33 log units) above; low and high end bracket the measured number.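

In this assay, benzyl isothiosemicarbazone in place of thiosemicarbazone gives, on the second core, a 3.5-fold higher number from compound 2 to compound 4 (0.54 log units; beyond the scatter). The change thus carries over between these two cores, in direction and, as far as the scatter allows, in size: the same change on two cores in this assay, a 9.1-fold higher number (0.96 log units; beyond the scatter) from compound 1 to compound 3 and a 3.5-fold higher number (0.54 log units; beyond the scatter) from compound 2 to compound 4, 2.6-fold (0.42 log units) apart, within the scatter of two such steps

Two cores remain only two cases, so this does not show that the step would hold on any other core, and the numbers alone do not say why the change weakens the read-out. The compounds shown leave open whether the step depends on the benzyl group itself, since a methyl group, a longer chain or a chain ending in an amine or a carboxylic acid in its place would test this. As far as these compounds go, it also remains open how the step behaves on a core carrying a methoxy or trifluoromethyl group instead of the methyl and chlorine seen so far.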